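Swapping the Dimethylphenyl Amide for a Chlorophenyl

The source may hold more compounds than are shown below. What is called first, only, known or untested is meant among the compounds shown, and "the series" means these compounds.

Compound 1 `Cc1cccc(NC(=O)CSc2nnc(-c3ccoc3C)n2Cc2ccco2)c1C` stands at the edge of what was measured: in a functional assay on CHO cells for antagonist activity at Orexin receptor type 2 (Homo sapiens), read by FLIPR and calcium flux (on this read-out higher numbers stand for weaker inhibition and lower numbers for stronger inhibition), compound 1 gives > 15800 nM, a limit rather than a number (the limit of > 15800 nM in this assay, at which 1 of the 2 values shown sits). Compound 3 `Cc1occc1-c1nnc(SCC(=O)Nc2cccc(Cl)c2)n1Cc1ccco1` differs from it in one place: 3-chlorophenyl in place of 2,3-dimethylphenyl on an amide-type nitrogen. Among the measured compounds shown here, the one measured step that bears on this change is an at least 100-fold lower number from compound 1 to compound 2 (2.00 log units; beyond the scatter), where compound 2 `Cc1occc1-c1nnc(SCC(=O)Nc2ccc(F)cc2)n1Cc1ccco1` gives 158 nM in this assay. A large downward step is therefore expected, an at least 52-fold lower number from compound 1 to compound 3 (1.72 log units; beyond the scatter). Compound 3 is estimated at 300 nM, with a range from 60 nM to 3000 nM.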

Compound 3, inhibition constant: 63.1 nM
The estimate for compound 3 lay 4.8-fold (0.68 log units) above the measured number; low and high end bracket the measured number.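

A second replacement now gives an at least 250-fold lower number from compound 1 to compound 3 (2.39 log units; beyond the scatter), so the large drop is not tied to 4-fluorophenyl alone. The group on this amide-type nitrogen still matters once 2,3-dimethylphenyl is gone, as the two replacements are separated by a 2.5-fold lower number from compound 2 to compound 3 (0.40 log units; beyond the scatter). Compound 1 stands at a limit of the assay, so the full size of the steps from it cannot be read: the limit of > 15800 nM in this assay, at which 1 of the 3 values shown sits.

From the compounds shown here alone, what a plain phenyl or a 4-chlorophenyl would give on this nitrogen remains open. So does whether a methoxyphenyl would follow the two halogen-bearing rings.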